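Phenyl in place of ethyl on the sulfanyl chain

The source may hold more compounds than are shown below. What is called first, only, known or untested is meant among the compounds shown, and "the series" means these compounds.

Measured compounds:
Compound 1 `CNc1nc(N)c2nc(O)n(Cc3ccccc3)c2n1`: in a functional assay (spleen, spleen) for activation, with Mus musculus as the target (on this read-out lower numbers stand for an effect already at smaller amounts and higher numbers for an effect only at larger amounts of compound), compound 1 gives 1 uM.
Compound 2 `CCSc1nc(N)c2nc(O)n(Cc3ccccc3)c2n1`: in this assay compound 2 gives 0.1 uM.
Compound 3 `CCCSc1nc(N)c2nc(O)n(Cc3ccccc3)c2n1`: in this assay compound 3 gives 0.01 uM.

Compound 3 has the lowest number of the three: its nearest neighbour is set apart by a 10-fold lower number from compound 2 to compound 3 (1.00 log units; beyond the scatter), its furthest by a 100-fold lower number from compound 1 to compound 3 (2.00 log units; beyond the scatter). Compound 4 `Nc1nc(SCc2ccccc2)nc2c1nc(O)n2Cc1ccccc1` differs from compound 3 by phenyl in place of ethyl on a saturated chain carbon bound to a sulfur. Among the measured compounds shown here, the steps that bear on this are a 10-fold lower number from compound 1 to compound 2 (1.00 log units; beyond the scatter) and a 10-fold lower number from compound 2 to compound 3 (1.00 log units; beyond the scatter), both enlarging the group on the sulfur and both lowering the number. As far as these compounds go, whether a phenyl continues that run is unknown from these three compounds, so only a small lowering or none beyond the scatter is expected. Compound 4 is expected at 0.01 uM, between 0.001 uM and 0.1 uM. That estimate corresponds to no change at the digits printed from compound 3 to compound 4 (within the scatter).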

Compound 4, minimum effective concentration: 0.1 uM
Estimate against measurement, compound 4: 10-fold (1.00 log units) below; measured number inside the range.
By their numbers in this assay, from the lowest: compound 3; then compounds 2 and 4 (each within the scatter of the next); then compound 1.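

In this assay, a larger group on the sulfur does not always mean a lower number: phenyl in place of ethyl brings a 10-fold higher number from compound 3 to compound 4 (1.00 log units; beyond the scatter), which reverses the trend seen across compounds 1, 2 and 3. Phenyl in place of methyl gives no change at the digits printed from compound 2 to compound 4 (within the scatter), while benzylsulfanyl in place of methylamino gives a 10-fold lower number from compound 1 to compound 4 (1.00 log units; beyond the scatter), so the sulfur-linked benzyl compound keeps its advantage over compound 1. Nothing available explains why the benzyl group differs from the propyl chain.

As far as these compounds go, whether a butyl or longer chain on the sulfur would go lower than compound 3 remains open. So does the effect of a phenethyl group, which would place the phenyl further along the chain.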